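From a Propargyl to an Isopentyl Chain

The compounds below may be only part of what the source reports. "The series", "measured", "known", "first", "only" and "open" are said of these compounds alone.

Compound 1 `C/C=C1/[C@H](O[C@@H]2O[C@H](COC(C)=O)[C@@H](OC(C)=O)[C@H](OC(C)=O)[C@H]2OC(C)=O)OC=C(C(=O)OC)[C@H]1CC(=O)O`: > 15000 nM
Compound 2 `C#CCOC(=O)C[C@@H]1C(C(=O)OC)=CO[C@@H](O[C@@H]2O[C@H](CO)[C@@H](O)[C@H](O)[C@H]2O)/C1=C/C`: > 15000 nM

Both entries come from a functional assay on SK-BR-3 cells (Homo sapiens) for antiproliferative activity, read by MTT assay, with a stated time of 72 h (a lower number here means a stronger inhibitor, a higher number a weaker inhibitor), and neither is an exact number. Compound 1 gives > 15000 nM, which is a limit. Compound 2 gives > 15000 nM, also a limit, so compound 2 stands at the limit of > 15000 nM in this assay, at which 2 of the 2 values shown sit.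

Compound 3 `C/C=C1/[C@H](O[C@@H]2O[C@H](CO)[C@@H](O)[C@H](O)[C@H]2O)OC=C(C(=O)OC)[C@H]1CC(=O)OCCC(C)C` differs from compound 2 in one place, with propargyl changed to isopentyl: isobutyl in place of ethynyl on a saturated chain carbon bound to an oxygen next to a carbonyl group.

No change beyond the scatter is expected in this assay, because of the limit of > 15000 nM in this assay, at which 2 of the 2 values shown sit. The expected step that the limit leaves unreadable from compound 2 to compound 3 is estimated to have no clear direction. Compound 3 is estimated at 20000 nM, with an expected range of 7000 nM to 50000 nM.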

Compound 3, half-maximal inhibitory concentration: 9020 nM
Estimate against measurement, compound 3: 2.2-fold (0.35 log units) above; the range from low to high includes it.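

In this assay, for the compounds shown here, compound 3 gives 9020 nM, the first exact number rather than a limit. The change from propargyl to isopentyl gives an at least 1.6-fold lower number from compound 2 to compound 3 (0.22 log units; that floor lies within the scatter), so this position can carry the isopentyl chain with activity that can be read. The true size of the step stays unknown because compound 2 has only a limit as its value: the limit of > 15000 nM in this assay, at which 2 of the 3 values shown sit.

Still open, from the compounds shown here alone, is whether a longer chain at this place would lower the number further. An amine or a carboxylic acid at the end of the chain is also untested among the compounds shown.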